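Extending the Methyl of Compound 2 to Ethyl

This account rests on a few compounds, and the source may have more. Where it says the series, first, only, none or still open, it means among the compounds named here.

Compound 1 `Cc1cc(-c2ccc(F)cc2)c(S(C)(=O)=O)cc1C(=O)N=C(N)N`: 36 nM
Compound 2 `Cc1cc(N2CCCCC2)c(S(C)(=O)=O)cc1C(=O)N=C(N)N`: 21 nM
Compound 3 `Cc1cc(Oc2cccnc2)c(S(C)(=O)=O)cc1C(=O)N=C(N)N`: 8.8 nM

In a functional assay for inhibition of sodium/hydrogen exchanger (Oryctolagus cuniculus) (on this read-out lower numbers stand for stronger inhibition and higher numbers for weaker inhibition), compound 2 gives 21 nM, the second highest of the three numbers. The nearest step is a 1.7-fold lower number from compound 1 to compound 2 (0.23 log units; within the scatter), the furthest is a 2.4-fold lower number from compound 2 to compound 3 (0.38 log units; beyond the scatter). Compound 4 `CCc1cc(N2CCCCC2)c(S(C)(=O)=O)cc1C(=O)N=C(N)N` differs from compound 2 by methyl in place of hydrogen on a saturated chain carbon bound to an aromatic carbon. Among the measured compounds shown here, none of the measured steps bears on this change: a 1.7-fold lower number from compound 1 to compound 2 (0.23 log units; within the scatter), a 4.1-fold lower number from compound 1 to compound 3 (0.61 log units; beyond the scatter) and a 2.4-fold lower number from compound 2 to compound 3 (0.38 log units; beyond the scatter) all exchange the group on an aromatic carbon, while the methyl-to-ethyl change sits elsewhere. The data give no ground to expect a step in this assay beyond the scatter in either direction. Compound 4 is therefore estimated at 21 nM, with a range of 8 nM to 55 nM. The step of no change at the digits printed from compound 2 to compound 4 (within the scatter) is expected to remain within the scatter.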

Compound 4, half-maximal inhibitory concentration: 25 nM
For compound 4 the middle estimate is 1.2-fold (0.08 log units) below the measured one, and the stated range covers the measured number.
By their numbers in this assay, from the lowest: compound 3; then compounds 2, 4 and 1 (each within the scatter of the next).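

Methyl to ethyl gives a 1.2-fold higher number from compound 2 to compound 4 (0.08 log units; within the scatter) in this assay, the only change shown at this place rather than at the group on an aromatic carbon. With piperidin-1-yl on the shared core, methyl in place of hydrogen on a saturated chain carbon bound to an aromatic carbon thus leaves the number within the scatter. Nothing available gives a reason for this result.

Going by these compounds, whether a propyl or isopropyl chain would also stay within the scatter remains open. So does whether ethyl would behave alike with the 4-fluorophenyl of compound 1 or the (pyridin-3-yl)oxy of compound 3.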